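The source may report more compounds than this note shows. Statements on the series, on what has been measured and on what is new or still open speak of the compounds shown alone.

Measured compounds:
compound 1 `CCCCCCCC/C=C/CCCCCCC(C)C(=O)Nc1c(OC)cc(OC)cc1OC` — 36 nM
compound 2 `CCCCCCCCCCCCCCC(=O)Nc1c(OC)cc(OC)cc1OC` — 65 nM
compound 3 `CCCCCCCCCCCCCCCC(=O)Nc1c(OC)cc(OC)cc1OC` — 54 nM

Three amides that share one core were tested in an assay on microsomes from intestine for inhibition of acyl-CoA:cholesterol acyltransferase (Oryctolagus cuniculus); a lower number here means a stronger inhibitor, a higher number a weaker inhibitor. Compound 3, with the structure shown above, stands second highest of the three numbers, yet its gaps to the other two are small: compound 2 sits a little higher and compound 1 a little lower, both within the usual scatter of this assay, so no order among the three can be claimed.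

Within the data shown here, the only single-point step among the measured compounds is a 1.2-fold lower number from compound 2 to compound 3 (0.08 log units; within the scatter), a methyl added far along the chain, which left the number essentially where it was. Compound 4 `CCCCCCCCCCCCCCC(C)C(=O)Nc1c(OC)cc(OC)cc1OC` arises from compound 3 by methyl in place of hydrogen on a saturated chain carbon bound to a carbonyl carbon and a saturated chain carbon. Among the measured compounds shown here, that methyl sits much closer to the carbonyl than the one in the measured step, so the measured step bears on it only loosely. Compound 1 also carries a methyl at that same place on its chain, together with a double bond further along, and gives 36 nM; with two changes at once it shows only that such a chain still gives a strong inhibitor.

On this basis compound 4 is expected to give 45 nM, within 20 nM to 110 nM, and the expected step of a 1.2-fold lower number from compound 3 to compound 4 (0.08 log units; within the scatter) is therefore one that stays within the scatter.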

Compound 4, half-maximal inhibitory concentration: 31 nM
The estimate for compound 4 lay 1.5-fold (0.16 log units) above the measured number; low and high end bracket the measured number.
By their numbers in this assay, from the lowest: compounds 4, 1, 3 and 2 (each within the scatter of the next, the first and the last beyond it).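

In this assay, a methyl on the saturated chain carbon bound to a carbonyl carbon and a saturated chain carbon gives a 1.7-fold lower number from compound 3 to compound 4 (0.24 log units; within the scatter) and so leaves compound 3 and compound 4 indistinguishable. Among these compounds, this shows that the shared core with a saturated chain keeps its strong inhibition with this methyl in place, which the earlier compounds could not show on their own, as compound 1 carries the same methyl only on a chain that also differs further along. The comparison with that chain gives a 1.2-fold lower number from compound 1 to compound 4 (0.06 log units; within the scatter) and so the double bond and extra length of compound 1 cannot be told apart from the shorter saturated chain of compound 4 in this assay.

These compounds leave open how much room there is on this carbon, for instance whether an ethyl, a second methyl, a hydroxyl or an amine there would still give a similar number. They also offer no measurement that explains why the methyl is accepted at this position.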